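From methoxy to nitro in a cytotoxicity test

The compounds below may be only part of what the source reports. "The series", "measured", "known", "first", "only" and "open" are said of these compounds alone.

In an ADME assay on Vero cells (Chlorocebus sabaeus) for cytotoxicity, read by crystal violet staining (on this read-out higher numbers stand for lower toxicity in this test and lower numbers for higher toxicity in this test), compound 1 `Clc1cccc(/N=N/N2CCCC2)c1` gives >= 100000 nM as its reading, which is a limit of the test and not a number. Going by the values given here, compound 2 `COc1ccc(/N=N/N2CCCC2)cc1` gives 90000 nM as the only true number so far. Compound 3 `O=[N+]([O-])c1ccc(/N=N/N2CCCC2)cc1` has nitro in place of methoxy on an aromatic carbon of compound 2 nitro in place of methoxy on an aromatic carbon and is still unmeasured. Among the compounds with values here, no measured step guides this change, so only a modest move toward lower numbers, meaning more toxicity, is expected in this assay. The estimated step is a 1.3-fold lower number from compound 2 to compound 3 (0.11 log units; within the scatter) in size. For compound 3 the estimate is 70000 nM with an expected range from 25000 nM to 100000 nM.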

Compound 3, half-maximal cytotoxic concentration: 90000 nM
For compound 3 the middle estimate is 1.3-fold (0.11 log units) below the measured one, within the range that was stated.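

On this aromatic carbon, nitro in place of methoxy gives no change at the digits printed from compound 2 to compound 3 (within the scatter) in this assay. Going by these compounds alone, this is the first direct comparison of two compounds that differ in one place, and the test does not tell these two groups apart. Both readings also lie close to the top of the scale, which ends in a limit: the limit of >= 100000 nM in this assay, at which 1 of the 3 values shown sits.

The compounds shown leave open whether an amine or a carboxylic acid on the same aromatic carbon would read differently. They also leave open whether any group at this place can produce a clear step in this test.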